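The source may hold more compounds than are shown below. What is called first, only, known or untested is meant among the compounds shown, and "the series" means these compounds.

Measured compounds: compound 1 `COc1ccc2c(c1)O[C@@H](c1cccc(O)c1O)[C@H](O)C2=O`; compound 2 `COc1ccc2c(c1)C(=O)[C@@H](O)[C@H](c1cccc(O)c1O)O2`; compound 3 `COc1cc2c(cc1OC)C(=O)[C@H](O)[C@@H](c1cccc(O)c1O)O2`.

In a functional assay on RAW264.7 cells (Rattus norvegicus) for inhibition, with RAW264.7 (Mus musculus) as the target, read by Griess assay, with stated times of 2 h and 16 h (on this read-out higher numbers stand for weaker inhibition and lower numbers for stronger inhibition), compound 1 gives 30300 nM. For compound 2 the result in this assay is a limit, > 100000 nM. In this assay compound 3 gives 50300 nM, the highest of the two numbers; its nearest neighbour is compound 1, and that gap lies within the scatter. Compound 4 `COc1cc2c(cc1OC)C(=O)[C@@H](O)[C@H](c1cccc(O)c1O)O2` differs from compound 3 only in configuration: the two compounds have the same atoms and bonds and differ only in configuration as drawn: 2 of 2 stereo elements differ (all stereocentres are inverted: mirror images); a stereocentre at a saturated ring carbon is drawn R in compound 3 and S in compound 4; a stereocentre at a saturated ring carbon is drawn R in compound 3 and S in compound 4. Going by the values given here, no measured pair shows such a step here, so its size is open; a move toward weaker inhibition in this assay, possibly reaching the limit, seems more likely than a gain. Compound 4 is therefore expected to give about 100000 nM, in the range 30000 nM to 300000 nM, which means a step of a 2.0-fold higher number from compound 3 to compound 4 (0.30 log units; within the scatter).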

Compound 4, half-maximal inhibitory concentration: > 100000 nM
Compound 4 gave a limit, no number; the forecaster's own chance of this, stated with the estimate: 45%; the middle value lies on the limit itself.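

In this assay, compounds 3 and 4 form the first mirror-image pair, and inverting both stereocentres gives an at least 1.9-fold higher number from compound 3 to compound 4 (0.29 log units; that floor lies within the scatter). With methoxy in place of hydrogen on an aromatic carbon, the data show an at least 3.3-fold higher number from compound 1 to compound 4 (0.51 log units; beyond the scatter). The step from compound 2 to compound 4 cannot be read, and larger changes stay hidden at the top of the range: the limit of > 100000 nM in this assay, at which 2 of the 4 values shown sit.

The compounds shown leave open whether the true configuration step lies beyond the scatter. They also leave open how an amine or a carboxylic acid in place of methoxy would read in either mirror-image form.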